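Silyl protection of the free sugar hydroxyl: cytotoxicity notes

A few compounds are considered here, and "the series" means these few. Any claim that something is new, unique, unknown or untested is made for them only; others in the source may bear on it.

Measured so far:
compound 1 `CSCO[C@@]1(C)CO[C@@](C)(CC(=O)OC[C@H]2O[C@@H](n3cc(C)c(=O)[nH]c3=O)C[C@@H]2O)C1` — 1000000 nM
compound 2 `Cc1cn([C@H]2C[C@H](O[Si](C)(C)C(C)(C)C)[C@@H](COC(=O)CC3(C)CC(C)(O)CO3)O2)c(=O)[nH]c1=O` — 200000 nM; 200000 nM (2 entries)
compound 3 `Cc1cn([C@H]2C[C@H](O)[C@@H](COC(=O)C[C@@]3(C)C[C@@](C)(O)CO3)O2)c(=O)[nH]c1=O` — a limit, > 1000000 nM

Among the compounds with values here, in a functional assay on C8166 cells (Homo sapiens) for cytotoxicity (on this read-out higher numbers stand for lower toxicity in this test and lower numbers for higher toxicity in this test), compound 1 gives 1000000 nM, the only plain single number in the set. Compound 2 gives 200000 nM; 200000 nM (2 entries) in this assay on two entries. Compound 3 reaches only the limit of this assay, > 1000000 nM. Within the data shown here, compound 1 thus stands as the one compound with a definite number; the remaining entries are a limit and a compound of a different core.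

Among the measured compounds shown here, the single measured step between compounds differing in one place is a number no lower from compound 1 to compound 3 (the limit leaves the size open); its size is hidden by the limit of > 1000000 nM in this assay, at which 1 of the 3 values shown sits, so the size of such a change stays unread.

Compound 4 `CSCO[C@@]1(C)CO[C@@](C)(CC(=O)OC[C@H]2O[C@@H](n3cc(C)c(=O)[nH]c3=O)C[C@@H]2O[Si](C)(C)C(C)(C)C)C1` differs from compound 1 by a group of 7 heavy atoms (6 carbon, 1 silicon; no ring) in place of a hydrogen atom, on an oxygen on a saturated carbon. For the measured compounds named here, no measured step covers this change. Compound 2 carries the same entering group on the same oxygen and sits at a plain number, whereas compound 3, with hydrogen there, sits at the limit; the two differ elsewhere as well, so they give a direction only. On that direction a downward step in this assay is expected, a 4.0-fold lower number from compound 1 to compound 4 (0.60 log units; beyond the scatter). Compound 4 is accordingly estimated at 250000 nM, with a range from 100000 nM to 1000000 nM.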

Compound 4, half-maximal cytotoxic concentration: 80000 nM
Beside the measured number, compound 4's estimate is 3.1-fold (0.49 log units) above it; measured number below the stated range.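

In this assay, the oxygen on a saturated carbon now carries a step of readable size: the group of 7 heavy atoms (6 carbon, 1 silicon; no ring) in place of a hydrogen atom gives a 13-fold lower number from compound 1 to compound 4 (1.10 log units; beyond the scatter). This position is therefore not silent on this read-out, since the change lies beyond the usual scatter and runs towards higher toxicity in this test, on a core that also carries the (methylsulfanyl)methyl group. Among the single-place changes, this is the only one with a size so far, as the step to compound 3 cannot be read, its value being a limit: the limit of > 1000000 nM in this assay, at which 1 of the 4 values shown sits.

A single pair gives no way to tell whether the drop follows the silicon atom or the whole size of the entering group, so a methyl or an acetyl group on the same oxygen would be the next useful comparison. Also open, on these data alone, is what an amine in place of that oxygen would do, and whether the same change would give a step of similar size on a core without the (methylsulfanyl)methyl group.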